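The source may report more compounds than this note shows. Statements on the series, on what has been measured and on what is new or still open speak of the compounds shown alone.

Working notes on the series. In a functional assay on HT-29 cells (Homo sapiens) for antiproliferative activity, read by MTT assay, with a stated time of 72 h (a lower number here means a stronger inhibitor, a higher number a weaker inhibitor), compound 1 (`Nc1nc(N)c2cc(CSC(=S)N3CCN(c4ccccc4)CC3)ccc2n1`) gives 2760 nM, compound 2 (`Cc1ccccc1N1CCN(C(=S)SCc2ccc3nc(N)nc(N)c3c2)CC1`) gives 2950 nM and compound 3 (`Nc1nc(N)c2cc(CSC(=S)N3CCN(c4ccc(F)cc4)CC3)ccc2n1`) gives 2050 nM. Compound 3 therefore stands level with the other two, with no separation beyond the scatter.

The next change leads to compound 4 (`Nc1nc(N)c2cc(CSC(=S)N3CCN(c4ccccn4)CC3)ccc2n1`), with pyridin-2-yl in place of 4-fluorophenyl on an amine nitrogen in a ring. Within the data shown here, no measured compound has a hetero atom in this aromatic ring, so the data do not test that feature directly.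

The closest evidence comes from the exchanges at the same nitrogen. The measured steps are a 1.1-fold higher number from compound 1 to compound 2 (0.03 log units; within the scatter), a 1.3-fold lower number from compound 1 to compound 3 (0.13 log units; within the scatter) and a 1.4-fold lower number from compound 2 to compound 3 (0.16 log units; within the scatter). The last of these is the exchange of one whole substituted aromatic group for another, and all three steps remain small. This pattern rests on compounds 1, 2 and 3 alone, and none of them goes against it. No step beyond the scatter is therefore expected in this assay, and neither direction is favoured.

The estimated change is a 1.3-fold higher number from compound 3 to compound 4 (0.10 log units; within the scatter). For compound 4 the expected value is 2600 nM, with an estimated range from 1300 nM to 5000 nM.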

Compound 4, half-maximal inhibitory concentration: 6200 nM
Beside the measured number, compound 4's estimate is 2.4-fold (0.38 log units) below it; measured number outside the range, above it.
By their numbers in this assay, from the lowest: compounds 3, 1 and 2 (each within the scatter of the next); then compound 4.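

In this assay, among these compounds, the exchange at this amine nitrogen gives the first steps beyond the scatter: the change to pyridin-2-yl gives a 3.0-fold higher number from compound 3 to compound 4 (0.48 log units; beyond the scatter) when 4-fluorophenyl leaves, a 2.1-fold higher number from compound 2 to compound 4 (0.32 log units; beyond the scatter) when 2-methylphenyl leaves and a 2.2-fold higher number from compound 1 to compound 4 (0.35 log units; beyond the scatter) when phenyl leaves. The position is therefore not indifferent to what it carries, even though the three aromatic rings of carbon only stand within the scatter of each other, and among these four compounds only the ring with a hetero atom and a hydrogen-bond acceptor separates from the rest, with no compound going against this. Nothing measured here bears on the reason for this rise in the number.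

A single ring with a hetero atom cannot show whether the step follows from the presence of that ring nitrogen or is particular to pyridin-2-yl. Going by these compounds, it also remains open whether a pyrimidine ring, or a saturated group such as cyclohexyl, on the same nitrogen would stay with compound 4 or with compounds 1, 2 and 3.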